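The source may hold more compounds than are shown below. What is called first, only, known or untested is meant among the compounds shown, and "the series" means these compounds.

In a functional assay on Jurkat cells (Homo sapiens) for antiproliferative activity, read by MTT assay (a lower number here means a stronger inhibitor, a higher number a weaker inhibitor), the measured compounds are:

compound 1, `COc1cc2c(cc1OC)C(=O)/C(=C/c1cccc(Cl)c1)CC2` — 9000 nM
compound 2, `COc1cc2c(cc1OC)C(=O)/C(=C/c1cc(Cl)cc(Cl)c1)CC2` — 7000 nM
compound 3, `COc1cc2c(cc1OC)C(=O)/C(=C/c1cccc(Cl)c1)C2` — 8000 nM

Compound 1 and compound 2 share a core and differ in one place, (chloro in place of hydrogen on an aromatic carbon). That change gave a 1.3-fold lower number from compound 1 to compound 2 (0.11 log units; within the scatter). Compound 3 stands on a different core; the difference between the two cores is not broken down here. The values of compound 1 and compound 3 lie within the scatter of each other.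

Compound 4, `COc1cc2c(cc1OC)C(=O)/C(=C/c1cc(Cl)cc(Cl)c1)C2`, carries the same change relative to compound 3, (chloro in place of hydrogen on an aromatic carbon), at a place described in the same words as before. Resting on the step from compound 1 to compound 2, a 1.3-fold lower number from compound 1 to compound 2 (0.11 log units; within the scatter), the step from compound 3 to compound 4 in this assay is expected to be a 1.2-fold lower number from compound 3 to compound 4 (0.09 log units; within the scatter). Compound 4 is therefore estimated at 6500 nM, most likely between 3500 nM and 12000 nM.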

Compound 4, half-maximal inhibitory concentration: 2000 nM
Beside the measured number, compound 4's estimate is 3.3-fold (0.51 log units) above it; measured number outside the range, below it.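

In this assay the same replacement of hydrogen by chloro on an aromatic carbon gave a 4.0-fold lower number from compound 3 to compound 4 (0.60 log units; beyond the scatter), and its size did not carry over from one core to the other: the same change on two cores in this assay, a 1.3-fold lower number (0.11 log units; within the scatter) from compound 1 to compound 2 and a 4.0-fold lower number (0.60 log units; beyond the scatter) from compound 3 to compound 4, 3.1-fold (0.49 log units) apart, beyond the scatter of two such steps

The change therefore counts for more on the core of compound 3 than on the core of compound 1, so a step measured on one of these cores is a poor guide to the other. This rests on a single pair per core and does not show what underlies the gap between the cores.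

The compounds shown leave open whether a fluoro group or an amine at the same place would also give steps that differ between the two cores. They also leave open whether the gap holds for chloro at other places on the ring.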